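A few compounds are considered here, and "the series" means these few. Any claim that something is new, unique, unknown or untested is made for them only; others in the source may bear on it.

In a functional assay on the whole organism for permeability, with Rattus norvegicus as the target, with a stated time of 8 h (on this read-out lower numbers stand for an effect already at smaller amounts and higher numbers for an effect only at larger amounts of compound), compound 1 `CCCCn1cc(C2CCN(Cc3ccc(OC)c(C(=O)O)c3)CC2)c2ccccc21` gives 0.13 mg/kg and compound 2 `COc1ccc(CN2CCC(c3cn(Cc4ccoc4)c4ccccc34)CC2)cc1C(=O)O` gives 0.2 mg/kg, so the two numbers lie within the scatter of each other. Compound 3 `COc1ccc(CN2CCC(c3cn(Cc4ccc(Cl)s4)c4ccccc34)CC2)cc1C(=O)O` carries 5-chlorothiophen-2-yl in place of furan-3-yl on a saturated chain carbon bound to an aromatic nitrogen. For the measured compounds named here, the only measured step at this place, a 1.5-fold higher number from compound 1 to compound 2 (0.19 log units; within the scatter), stayed within the scatter, so no step beyond the scatter is expected in this assay. Going by the values given here, no measured compound carries the entering group, which leaves the expectation uncertain. The estimated step is no change at the digits printed from compound 2 to compound 3 (within the scatter). For compound 3 the expected value is 0.2 mg/kg, with an estimated range of 0.07 mg/kg to 0.6 mg/kg.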

Compound 3, dose for half-maximal effect: 0.7 mg/kg
Estimate against measurement, compound 3: 3.5-fold (0.54 log units) below; the whole stated range lies below it.
By their numbers in this assay, from the lowest: compounds 1 and 2 (each within the scatter of the next); then compound 3.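

For the compounds shown here, at this place, on a saturated chain carbon bound to an aromatic nitrogen, the choice of group can now be seen to matter: 5-chlorothiophen-2-yl gives the first steps beyond the scatter (a 3.5-fold higher number from compound 2 to compound 3 (0.54 log units; beyond the scatter)) and (a 5.4-fold higher number from compound 1 to compound 3 (0.73 log units; beyond the scatter)). Propyl and furan-3-yl had stayed within the scatter of each other, so the five-membered aromatic ring alone does not settle the outcome. Nothing available explains this step. Going by these compounds, it remains open whether the chlorine or the sulfur matters more. Plain thiophen-2-yl and 5-chlorofuran-2-yl would separate the two.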